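Replacing a methylimidazole with a trimethylpyrazole: expected lipophilicity

The source may report more compounds than this note shows. Statements on the series, on what has been measured and on what is new or still open speak of the compounds shown alone.

Measured compounds and their values:
Compound 1, `Cc1cc(Cl)c(-c2cn(C)cn2)cc1NC(=O)c1ccc(OCc2ccccn2)cc1`, gives 3.1
Compound 2, `Cc1ccc(-c2c[nH]cn2)cc1NC(=O)c1ccc(OCc2ccccn2)cc1`, gives 2.8
Compound 3, `Cc1ncc(-c2cc(NC(=O)c3ccc(OCc4ccccn4)cc3)c(C)cc2C)[nH]1`, gives 2.8

Of the compounds shown here, three built on one shared core have so far been measured in a physicochemical assay for lipophilicity; a higher number here means a more lipophilic compound, a lower number a more polar compound. Compound 3 stands level with compound 2 at the digits given, and together they form the lowest pair of the three numbers; compound 1 sits somewhat higher, but that gap stays within the scatter of this assay, so no order among the three can be claimed.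

Compound 4, `Cc1cc(C)c(-c2c(C)nn(C)c2C)cc1NC(=O)c1ccc(OCc2ccccn2)cc1`, has not yet been measured. It differs from compound 3 in one place: 1,3,5-trimethyl-1H-pyrazol-4-yl in place of 2-methyl-1H-imidazol-5-yl on an aromatic carbon. Among the compounds with values here, no measured pair in this set is separated by this particular exchange, so the size of the step can only be expected, not read off. The entering group is larger by the count given and carries no hydrogen-bond donor where the leaving group carries one. On that basis the step of a number 0.60 log units higher from compound 3 to compound 4 (beyond the scatter) is expected to be upward and beyond the scatter of this assay. Compound 4 is accordingly estimated at about 3.4, with a range from 3 to 3.8.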

Compound 4, distribution coefficient: > 3
Compound 4 was reported as a limit; the forecaster's own chance of this, stated with the estimate: 2%; the middle value does not contradict the limit.
By their numbers in this assay, from the lowest: compounds 2, 3 and 1 (each within the scatter of the next).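

In this assay compound 4 gives > 3 as a limit of the assay, not a number. The exchange of 2-methyl-1H-imidazol-5-yl for 1,3,5-trimethyl-1H-pyrazol-4-yl, on an aromatic carbon ortho to a methyl group and para to a methyl group, can be read only as a lower bound: a number at least 0.20 log units higher from compound 3 to compound 4 (that floor lies within the scatter). Within the data shown here, this is the only step in the set that can be read at this position, and it is bounded on one side only, with compound 4 standing at the edge of the measured range: the limit of > 3 in this assay, at which 1 of the 4 values shown sits.

As far as these compounds go, whether the true step lies beyond the scatter remains open. Also open, from the compounds shown here alone, is how a 1H-pyrazol-4-yl without its three methyl groups, or a carboxylic acid at this position, would stand in this assay.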